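The compounds below may be only part of what the source reports. "The series", "measured", "known", "first", "only" and "open" are said of these compounds alone.

The study concerns a small set of imines on a shared core, tested in a functional assay on the whole organism (strain Swiss albino) with Mus musculus as the target, in the maximal electroshock model, with a stated time of 0.5 h; a higher number here means that more compound is needed for the effect, a lower number that less compound is needed. Compound 1 `C/C(=N\Cc1cccnc1)c1cccc(N)c1` gives 30 mg/kg in this assay. Compound 2 `O=[N+]([O-])c1ccc(/C=N/Cc2cccnc2)cc1` gives 100 mg/kg in this assay. Compound 3 `COc1ccc(/C=N/Cc2cccnc2)cc1OC` gives 300 mg/kg in this assay. Among these three numbers compound 2 stands second highest: its nearest neighbour is compound 3, whose number is higher by a margin beyond the scatter, and its furthest is compound 1, whose number is lower by a margin beyond the scatter. Among the compounds with values here, no two measured compounds differ in only one place, so no measured step is available as a guide.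

The unmeasured compound 4 `C(=N/Cc1cccnc1)\c1ccccc1` departs from compound 2 by a single change: hydrogen in place of nitro on an aromatic carbon. Within the data shown here, nothing among the measured compounds shows what this change alone does in this assay; the values of compound 2 and compound 3 show only that a different group on the same ring can shift the number beyond the scatter. Among the measured compounds shown here, with no closer precedent, compound 4 is expected to stay near compound 2. The step of no change at the digits printed from compound 2 to compound 4 (within the scatter) is expected to be no larger than the usual scatter, in either direction. The estimate for compound 4 is 100 mg/kg, with a range from 30 mg/kg to 300 mg/kg.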

Compound 4, minimum effective dose: 100 mg/kg
Compound 4: middle estimate and measured number agree at the digits printed; the range from low to high includes it.
By their numbers in this assay, from the lowest: compound 1; then compounds 2 and 4 (each within the scatter of the next); then compound 3.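

In this assay, within the data shown here, this gives the first measured step in the set that differs in one place only: no change at the digits printed from compound 2 to compound 4 (within the scatter). At this aromatic carbon, para to a group of 9 heavy atoms, the nitro group and a bare hydrogen cannot be told apart, so in this pair the nitro group, with its 3 heavy atoms and 2 hydrogen-bond acceptors, is not needed for a number at this level. Nothing measured on the compounds here accounts for this result, and the step stands as an observation without an explanation.

One pair at one position cannot show whether this position tolerates substitution in general, and a chlorine atom, a carboxylic acid or a longer alkyl chain on the same aromatic carbon might still move the number beyond the scatter. Among these compounds, also open is what the methyl group on the imine carbon of compound 1 does by itself, and what the amine on its ring does by itself, since no pair here separates either one.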